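A Nitrile in Place of Trifluoromethyl on the Amide Aryl

This account rests on a few compounds, and the source may have more. Where it says the series, first, only, none or still open, it means among the compounds named here.

Two close relatives of one shared core have been tested in a functional assay on HCC1937 cells (Homo sapiens) for antiproliferative activity, read by CCK-8 assay, with a stated time of 72 h; on this read-out higher numbers stand for weaker inhibition and lower numbers for stronger inhibition. Compound 1 `O=C(Nc1cccc(-c2oc3cc(-c4ccc(F)cc4)ccc3c(=O)c2O)c1)c1ccc(F)cc1` gives 14200 nM. Compound 2 `O=C(Nc1cccc(-c2oc3cc(-c4ccc(F)cc4)ccc3c(=O)c2O)c1)c1ccc(C(F)(F)F)cc1`, in which trifluoromethyl replaces fluoro on an aromatic carbon, gives 7350 nM. Among the measured compounds shown here, the only step measured so far, a 1.9-fold lower number from compound 1 to compound 2 (0.29 log units; within the scatter), is too small to count as a real difference, so compound 2 holds the lower of the two numbers without standing clearly apart from compound 1.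

Compound 3 `N#Cc1ccc(C(=O)Nc2cccc(-c3oc4cc(-c5ccc(F)cc5)ccc4c(=O)c3O)c2)cc1` is the next member, not yet measured in this assay. It differs from compound 2 as follows: cyano in place of trifluoromethyl on an aromatic carbon. For the measured compounds named here, the one measured step bears on it only loosely, since it concerns the same position but a different pair of groups, and it stayed within the scatter. Nothing in these two values points to a large move in either direction. Compound 3 is therefore expected to give a number close to that of compound 2, with a 1.2-fold higher number from compound 2 to compound 3 (0.09 log units; within the scatter) as the likely step. The estimate for compound 3 is 9000 nM, within a range from 3500 nM to 25000 nM.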

Compound 3, half-maximal inhibitory concentration: 2990 nM
Beside the measured number, compound 3's estimate is 3.0-fold (0.48 log units) above it; the whole stated range lies above it.
By their numbers in this assay, from the lowest: compound 3; then compounds 2 and 1 (each within the scatter of the next).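

Until now, this position on the amide aryl had shown no change beyond the scatter, so it could have seemed indifferent to what sits there, but in this assay the nitrile gives the first clear shift, with a 2.5-fold lower number from compound 2 to compound 3 (0.39 log units; beyond the scatter) when it replaces trifluoromethyl and a 4.7-fold lower number from compound 1 to compound 3 (0.68 log units; beyond the scatter) when it replaces fluoro. Both steps are modest, yet both lie beyond the scatter, which makes compound 3 the most potent of the three and shows that antiproliferative activity in these cells does depend on the group at this aromatic carbon. Cyano has 2 heavy atoms and 1 hydrogen-bond acceptor where trifluoromethyl has 4 heavy atoms and 0 hydrogen-bond acceptors, but no supporting measurement shows whether either difference accounts for the shift.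

Going by these compounds, three compounds cannot show how far this trend extends, so it remains open whether an amine, a carboxylic acid or a methoxy group on the same aromatic carbon would lower the number further or raise it again. On these data alone, it is also open whether the nitrile would give a similar shift with a different group in place of the 4-fluorophenyl on the shared core.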